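From 5-hydroxypentyl to 5-azidopent-1-yn-1-yl on the shared core

The compounds below may be only part of what the source reports. "The series", "measured", "known", "first", "only" and "open" are said of these compounds alone.

Measured in a functional assay for inhibition, with Homo sapiens as the target; on this read-out lower numbers stand for stronger inhibition and higher numbers for weaker inhibition:
Compound 1 `CC#CCC(C)[C@H](O)/C=C/[C@H]1[C@H](O)C[C@]2(CCCCCO)C/C(=C/CCCC(=O)O)C[C@H]12` gives 11000 nM
Compound 2 `CC#CCC(C)[C@H](O)/C=C/[C@H]1[C@H](O)C[C@]2(CCCCCO)C/C(=C\CCCC(=O)O)C[C@H]12` gives 7000 nM
Compound 3 `CC#CCC(C)[C@H](O)/C=C/[C@H]1[C@H](O)C[C@]2(CCCCCN=[N+]=[N-])C/C(=C\CCCC(=O)O)C[C@H]12` gives 500 nM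

Compound 1 and compound 2 lie together at the top of these numbers, with a 1.6-fold lower number from compound 1 to compound 2 (0.20 log units; within the scatter) between them, while compound 3 stands well below. Compound 4 `CC#CCC(C)[C@H](O)/C=C/[C@H]1[C@H](O)C[C@]2(C#CCCCN=[N+]=[N-])C/C(=C/CCCC(=O)O)C[C@H]12` keeps the core of compound 1 and carries one change, (5-azidopent-1-yn-1-yl in place of 5-hydroxypentyl on a saturated ring carbon), with 5-azidopent-1-yn-1-yl in place of 5-hydroxypentyl on a saturated ring carbon. The closest measured precedent is a 14-fold lower number from compound 2 to compound 3 (1.15 log units; beyond the scatter), which also brings in azido for hydroxy. Among the measured compounds shown here, no measured compound carries the triple bond, so a somewhat smaller drop is expected. The estimated step in this assay is downward and large, an 11-fold lower number from compound 1 to compound 4 (1.04 log units; beyond the scatter). Compound 4 is expected at 1000 nM, within an estimated range of 250 nM to 5000 nM.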

Compound 4, half-maximal inhibitory concentration: 850 nM
The estimate for compound 4 lay 1.2-fold (0.07 log units) above the measured number; low and high end bracket the measured number.
By their numbers in this assay, from the lowest: compounds 3 and 4 (each within the scatter of the next); then compounds 2 and 1 (each within the scatter of the next).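

In this assay, changing 5-hydroxypentyl to 5-azidopent-1-yn-1-yl on this saturated ring carbon gives a 13-fold lower number from compound 1 to compound 4 (1.11 log units; beyond the scatter) as a large downward step, so such a drop is not confined to the double-bond form of compound 2. The azido group and the triple bond enter together here, so their shares cannot be separated. Nothing shown accounts for the step. From the compounds shown here alone, it remains open what 5-hydroxypent-1-yn-1-yl would give with the triple bond alone, and whether an amine in place of azido or a longer chain would keep the lower number.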